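This account rests on a few compounds, and the source may have more. Where it says the series, first, only, none or still open, it means among the compounds named here.

In a functional assay on PC-3 cells (Homo sapiens) for cytotoxicity, read by MTT assay, with a stated time of 72 h (a lower number here means a stronger inhibitor, a higher number a weaker inhibitor), compound 3 `O=S(=O)(c1ccc(Br)cc1)c1nc2ccccc2nc1N1CCCC(O)C1` gives 3690 nM, the second highest of the three numbers measured. Compound 2 `O=S(=O)(c1ccccc1)c1nc2ccccc2nc1N1CCCC(O)C1` gives 2100 nM, and compound 1 `O=S(=O)(c1ccc(F)cc1)c1nc2ccccc2nc1N1CCc2ccccc2C1` gives 9230 nM; the gap from compound 3 to compound 2 lies within the scatter, while that to compound 1 lies beyond it. Compound 4 `O=S(=O)(c1ccc(F)cc1)c1nc2ccccc2nc1N1CCCC(O)C1` differs from compound 3 by fluoro in place of bromo on an aromatic carbon, which read one bond further out is 4-bromophenyl to 4-fluorophenyl. For the measured compounds named here, the only measured step touching that aromatic carbon is a 1.8-fold higher number from compound 2 to compound 3 (0.24 log units; within the scatter), bromo entering for hydrogen. Since that step stayed within the scatter, no step beyond the scatter is expected for compound 4, and the expected step is a 1.2-fold lower number from compound 3 to compound 4 (0.09 log units; within the scatter). Compound 4 is therefore estimated at 3000 nM, with a range from 1200 nM to 7500 nM.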

Compound 4, half-maximal inhibitory concentration: 2130 nM
For compound 4 the middle estimate is 1.4-fold (0.15 log units) above the measured one; low and high end bracket the measured number.
By their numbers in this assay, from the lowest: compounds 2, 4 and 3 (each within the scatter of the next); then compound 1.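

In this assay, the step of a 1.7-fold lower number from compound 3 to compound 4 (0.24 log units; within the scatter) and the step of a 1.0-fold higher number from compound 2 to compound 4 (0.01 log units; within the scatter) both stay within the scatter, so hydrogen, fluoro and bromo on this aromatic carbon cannot be told apart. The amine part counts for more: with 3-hydroxypiperidin-1-yl in place of 1,2,3,4-tetrahydroisoquinolin-2-yl, the step of a 4.3-fold lower number from compound 1 to compound 4 (0.64 log units; beyond the scatter) lies beyond the scatter. Nothing given here explains these numbers. As far as these compounds go, whether an amine or a carboxylic acid on that aromatic carbon would also leave the number unmoved stays open, as does whether the 3-hydroxypiperidin-1-yl advantage holds with bromo or hydrogen on the ring.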